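Enlarging the Amide Substituent in an Adenosine Receptor Series

The source may report more compounds than this note shows. Statements on the series, on what has been measured and on what is new or still open speak of the compounds shown alone.

Of the compounds shown here, three built on one shared core have been measured in an assay on CHO cells for displacement of a labelled ligand from adenosine receptor A3 (Homo sapiens); on this read-out higher numbers stand for weaker inhibition and lower numbers for stronger inhibition. Compound 1 `CNC(=O)[C@H]1O[C@@H](n2cnc3c(N)nc(Cl)nc32)[C@H](O)[C@@H]1O` gives 0.398 nM. Compound 2 `CNC(=O)[C@H]1O[C@@H](n2cnc3c(NC)nc(Cl)nc32)[C@H](O)[C@@H]1O` gives 0.282 nM, and the step of a 1.4-fold lower number from compound 1 to compound 2 (0.15 log units; within the scatter) corresponds to a methyl in place of hydrogen on a nitrogen on an aromatic ring. Compound 3 `CNc1nc(Cl)nc2c1ncn2[C@@H]1O[C@H](C(=O)NC2CC2)[C@@H](O)[C@H]1O` gives 2.82 nM, the highest number of the three, with compound 1 its nearest neighbour and compound 2 the furthest; the step of a 10-fold higher number from compound 2 to compound 3 (1.00 log units; beyond the scatter) comes from cyclopropyl in place of methyl on an amide-type nitrogen.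

Compound 4 `CNc1nc(Cl)nc2c1ncn2[C@@H]1O[C@H](C(=O)NCCC(C)C)[C@@H](O)[C@H]1O` has not yet been measured. It differs from compound 3 by isopentyl in place of cyclopropyl on an amide-type nitrogen: isopentyl takes the place of cyclopropyl on the amide-type nitrogen whose other neighbour is the carbonyl carbon. Among the measured compounds shown here, only one measured step touches this position, a 10-fold higher number from compound 2 to compound 3 (1.00 log units; beyond the scatter), and there the exchange of methyl for cyclopropyl raised the number in this assay. Isopentyl is another change at the same place, so a further rise is expected, estimated as a 2.1-fold higher number from compound 3 to compound 4 (0.33 log units; beyond the scatter). Compound 4 is therefore expected to give 6 nM in this assay, within a range from 1.5 nM to 25 nM.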

Compound 4, inhibition constant: 1.62 nM
Beside the measured number, compound 4's estimate is 3.7-fold (0.57 log units) above it, within the range that was stated.
By their numbers in this assay, from the lowest: compounds 2 and 1 (each within the scatter of the next); then compounds 4 and 3 (each within the scatter of the next).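

In this assay, the step of a 1.7-fold lower number from compound 3 to compound 4 (0.24 log units; within the scatter) shows that this amide-type nitrogen takes isopentyl, an open chain of 5 heavy atoms, with no reading apart from cyclopropyl, a three-membered ring of 3 heavy atoms. The comparison with the methyl amide gives a 5.7-fold higher number from compound 2 to compound 4 (0.76 log units; beyond the scatter), so the higher number seen with cyclopropyl is also seen with a group that has no ring, and among these three groups the number does not keep climbing from cyclopropyl to the larger isopentyl. Nothing available explains why methyl gives the lower number at this position.

Still open, from the compounds shown here alone, is whether ethyl on the same nitrogen would read with methyl or with the other two groups, and whether a longer chain, or a chain ending in an amine or a carboxylic acid, would stay in the same range. The compounds shown also leave open how the amide groups would behave in any read-out other than this assay.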